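The compounds below may be only part of what the source reports. "The series", "measured", "known", "first", "only" and "open" are said of these compounds alone.

Measured so far in a functional assay on HepG2 cells (Homo sapiens) for inhibition, read by MTT assay, with a stated time of 72 h; a lower number here means a stronger inhibitor, a higher number a weaker inhibitor:
- compound 1 `CC(C)(C)n1cc2c(n1)C(=O)CC1(CCN(C(=O)c3cc(-c4ccc(N)cc4)nc4ccccc34)CC1)O2` at 630 nM
- compound 2 `CN1CCN(c2cc(C(=O)N3CCC4(CC3)CC(=O)c3nn(C(C)(C)C)cc3O4)c3ccccc3n2)CC1` at 9550 nM

Compound 2 holds the higher of the two numbers, and its gap to compound 1 lies beyond the scatter. Compound 3 `COc1cc(C(=O)N2CCC3(CC2)CC(=O)c2nn(C(C)(C)C)cc2O3)c2ccccc2n1` has yet to be measured in this assay and differs from compound 2 as follows: methoxy in place of 4-methylpiperazin-1-yl on an aromatic carbon (methoxy in place of 4-methylpiperazin-1-yl on an aromatic carbon, next to the ring nitrogen).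

For the measured compounds named here, the only measured step at this carbon is a 15-fold higher number from compound 1 to compound 2 (1.18 log units; beyond the scatter) (large), with 4-methylpiperazin-1-yl in place of 4-aminophenyl. Going by the values given here, the number therefore moved strongly with the group at this carbon, but two compounds show no trend and no methoxy compound has been measured. Compound 1, which lacks 4-methylpiperazin-1-yl, sits at 630 nM and so a move toward a lower number is expected, smaller than the measured step and only loosely fixed. The expected step is a 2.4-fold lower number from compound 2 to compound 3 (0.38 log units; beyond the scatter) with wide uncertainty. For compound 3 the estimate is 4000 nM with 1300 nM to 12000 nM as the expected range.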

Compound 3, half-maximal inhibitory concentration: > 10000 nM
Compound 3 gave a limit, no number; the forecaster's own chance of this, stated with the estimate: 15%; at least 2.5-fold (0.39 log units) between middle value and limit.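

In this assay compound 3 gives a limit, > 10000 nM, and not a number. Methoxy in place of 4-aminophenyl on this aromatic carbon gives an at least 15-fold higher number from compound 1 to compound 3 (1.20 log units; beyond the scatter) (large), so a second group, this one small and without a ring, also falls well short of 4-aminophenyl, and among the three compounds only the 4-aminophenyl group keeps the number clearly low. Methoxy in place of 4-methylpiperazin-1-yl gives an at least 1.0-fold higher number from compound 2 to compound 3 (0.01 log units; that floor lies within the scatter) and so these two groups stay unordered, and the top of the range is reached only once in the series so far: the limit of > 10000 nM in this assay, at which 1 of the 3 values shown sits.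

As far as these compounds go, it remains open whether the gain with 4-aminophenyl belongs to the aromatic ring or to its amine, a question that a plain phenyl group at this carbon would separate. Also open, from the compounds shown here alone, is how much the placing of that amine counts, which a 3-aminophenyl or a 4-hydroxyphenyl group on the same carbon of the shared core would begin to answer.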